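The compounds below may be only part of what the source reports. "The series", "measured", "known", "first", "only" and "open" are said of these compounds alone.

Of the compounds shown here, three of one shared core have been measured in an assay on isolated protein for inhibition of high affinity 3',5'-cyclic-AMP phosphodiesterase 7A (Homo sapiens), read by scintillation proximity assay and cAMP accumulation, with a stated time of 20 min, tested at 10 uM; a lower number here means less inhibition, a higher number more inhibition at the concentration tested (going by the name of the read-out). Compound 1, `COc1cc(COC(=O)c2ccco2)cc(OC)c1OC`, carries a hydrogen at the position of interest and gives 10%. Compound 2, `COc1cc(COC(=O)c2ccc(C)o2)cc(OC)c1OC`, carries a methyl there and gives -9.9%. Compound 3, `COc1cc(COC(=O)c2ccc(-c3ccccc3Cl)o2)cc(OC)c1OC`, carries a 2-chlorophenyl at that position and gives 34.6%, the highest of the three numbers, with compound 1 nearest and compound 2 furthest. The two steps into compound 3 are a number 24.6 percentage points higher from compound 1 to compound 3 (beyond the scatter) and a number 44.5 percentage points higher from compound 2 to compound 3 (beyond the scatter); the step of a number 19.9 percentage points lower from compound 1 to compound 2 (beyond the scatter) runs the other way.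

Compound 4, `COc1ccc(-c2ccc(C(=O)OCc3cc(OC)c(OC)c(OC)c3)o2)cc1`, has not been measured. It differs from compound 3 in one place: 4-methoxyphenyl in place of 2-chlorophenyl on an aromatic carbon. Going by the values given here, the measured steps show that a six-membered aromatic ring at this position raises inhibition over hydrogen or methyl, but no measured pair exchanges one such ring for another, so the effect of swapping the 2-chlorophenyl for the 4-methoxyphenyl cannot be read from the data. The account therefore expects compound 4 to keep most of the gain seen in compound 3, with a step of a number 4.6 percentage points lower from compound 3 to compound 4 (within the scatter) that is estimated to lie within the scatter. The estimate for compound 4 in this assay is 30%, expected to fall between 10% and 50%.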

Compound 4, a percentage reported as inhibition, at one concentration (the size of the read-out at that concentration, not a potency): 14%
The estimate for compound 4 lay 16 percentage points above the measured number, within the range that was stated.
By their numbers in this assay, from the lowest: compound 2; then compounds 1 and 4 (each within the scatter of the next); then compound 3.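

In this assay the exchange of one six-membered aromatic ring for another at this position gives a number 20.6 percentage points lower from compound 3 to compound 4 (beyond the scatter) and so shows that such a ring does not carry the rise on its own: what the ring bears, or where it bears it, counts as well. Set against hydrogen, the 4-methoxyphenyl gives a number 4 percentage points higher from compound 1 to compound 4 (within the scatter) and thus no readable gain, while set against methyl it gives a number 23.9 percentage points higher from compound 2 to compound 4 (beyond the scatter) and so the clear rise over hydrogen belongs to the 2-chlorophenyl alone among these groups. Nothing measured here bears on why the two rings part in this way.

The two rings differ both in the atom they carry and in where they carry it, so the compounds shown cannot separate these two changes, and a plain phenyl, a 4-chlorophenyl or a 2-methoxyphenyl at this position would be needed to do so. They also leave open how an amine or a carboxylic acid on this ring would compare with the 2-chlorophenyl.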